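Imidazole linker shortening in an EP3 antagonist series

This account rests on a few compounds, and the source may have more. Where it says the series, first, only, none or still open, it means among the compounds named here.

Compound 1 `CC(C)C(Cc1ncc[nH]1)c1ccc(-c2ccc3cccc(F)c3c2)[nH]c1=O` is the reference point here. In a functional assay on CHO cells for antagonist activity at prostaglandin E2 receptor EP3 subtype (Homo sapiens), read by cAMP accumulation (on this read-out higher numbers stand for weaker inhibition and lower numbers for stronger inhibition), compound 1 gives 76 nM, the highest of the three numbers measured; compound 3 `CC(C)C(Cc1noc(=O)[nH]1)c1ccc(-c2ccc3cccc(F)c3c2)[nH]c1=O` gives 70 nM and compound 2 `Cc1nc(C(c2ccc(-c3ccc4cccc(F)c4c3)[nH]c2=O)C(C)C)[nH]c1C` gives 50 nM, and the three sit within the scatter of one another, so no order among them is claimed.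

Compound 4 `CC(C)C(c1ncc[nH]1)c1ccc(-c2ccc3cccc(F)c3c2)[nH]c1=O` differs from compound 1 in one place: 1H-imidazol-2-yl in place of (1H-imidazol-2-yl)methyl on a saturated chain carbon bound to an aromatic carbon and a saturated chain carbon. The step that bears most directly on this change is a 1.5-fold lower number from compound 1 to compound 2 (0.18 log units; within the scatter), which also brings the ring onto the chain carbon, though with two added methyl groups. The step of a 1.1-fold lower number from compound 1 to compound 3 (0.04 log units; within the scatter) shows that swapping the ring itself changes little in this series.

For compound 4 the change is therefore expected to leave the number near compound 1, with no step beyond the scatter, a 1.3-fold lower number from compound 1 to compound 4 (0.10 log units; within the scatter). Compound 4 is estimated at 60 nM, with a range from 30 nM to 130 nM.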

Compound 4, half-maximal inhibitory concentration: 33 nM
Estimate against measurement, compound 4: 1.8-fold (0.26 log units) above; the measured number falls inside the stated range.
By their numbers in this assay, from the lowest: compounds 4, 2, 3 and 1 (each within the scatter of the next, the first and the last beyond it).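

In this assay, going by these compounds alone, 1H-imidazol-2-yl in place of (1H-imidazol-2-yl)methyl gives a 2.3-fold lower number from compound 1 to compound 4 (0.36 log units; beyond the scatter) as the first step to pass the scatter, though only a modest one. The same position gives a 2.1-fold lower number from compound 3 to compound 4 (0.33 log units; beyond the scatter) as a second modest step, so compound 4 separates from both compounds that carry a ring one chain carbon further out. With the ring on the chain carbon in both compounds, a 1.5-fold lower number from compound 2 to compound 4 (0.18 log units; within the scatter) and the 4,5-dimethyl substitution makes no readable difference.

Nothing available accounts for these steps. Open, going by these compounds, is whether a longer two-carbon chain to the imidazole, or a carboxylic acid or a primary amine on the same saturated chain carbon, would follow compound 4 or compound 1.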